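The source may report more compounds than this note shows. Statements on the series, on what has been measured and on what is new or still open speak of the compounds shown alone.

The measured compounds are:

compound 1, `O=C1C[C@H]2O[C@H]([C@H](O)c3ccccc3)[C@H](O)[C@H]2O1`: 410 nM
compound 2, `CO[C@H](c1ccccc1)[C@H]1O[C@@H]2CC(=O)O[C@@H]2[C@H]1O`: 7950 nM

Going by the values given here, in a functional assay on K562 cells (Homo sapiens) for inhibition, read by MTT assay, with a stated time of 72 h (a higher number here means a weaker inhibitor, a lower number a stronger inhibitor), compound 2 gives 7950 nM, the higher of the two numbers measured so far; its nearest neighbour is compound 1, which gives 410 nM. The step from compound 1 to compound 2 was a 19-fold higher number from compound 1 to compound 2 (1.29 log units; beyond the scatter), a large change that lies beyond the scatter.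

Compound 3, `CO[C@@H]1[C@H]2OC(=O)C[C@H]2O[C@@H]1[C@H](OC)c1ccccc1`, differs from compound 2 by methyl in place of hydrogen on an oxygen on a saturated carbon. Among the compounds with values here, the one measured step that bears on this change is the same kind of exchange, hydroxy to methoxy, on the other oxygen, and it was a 19-fold higher number from compound 1 to compound 2 (1.29 log units; beyond the scatter). On this single precedent a further rise in the number is expected for compound 3, though on a different oxygen the size is uncertain, so a smaller step of a 2.5-fold higher number from compound 2 to compound 3 (0.40 log units; beyond the scatter) is estimated. Compound 3 is therefore expected to give about 20000 nM, in the range 6000 nM to 80000 nM.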

Compound 3, half-maximal inhibitory concentration: 14700 nM
Beside the measured number, compound 3's estimate is 1.4-fold (0.13 log units) above it, within the range that was stated.
By their numbers in this assay, from the lowest: compound 1; then compounds 2 and 3 (each within the scatter of the next).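

In this assay the exchange of hydroxy to methoxy at this oxygen gives a step that lies within the scatter (a 1.8-fold higher number from compound 2 to compound 3 (0.27 log units; within the scatter)), whereas the same exchange on the other oxygen gave a step beyond it (a 19-fold higher number from compound 1 to compound 2 (1.29 log units; beyond the scatter)). The same methyl in place of hydrogen therefore does not read alike at the two oxygens, and this position, unlike the first, shows no resolved change between its hydroxy and methoxy forms. Nothing shown explains this contrast between the two oxygens.

The compounds shown do not tell whether this position would stay as flat with a longer chain on the oxygen, such as ethoxy or benzyloxy. They also leave open what an amine or a fluorine in place of the hydroxy would give on the core of compound 2.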